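This account rests on a few compounds, and the source may have more. Where it says the series, first, only, none or still open, it means among the compounds named here.

Compound 3 `COc1cc(/C=C/C(=O)Nc2ccccc2)ccc1OCCCCCCN1CCCCC1` gives 1.77 in a physicochemical assay for lipophilicity, using the shake flask method, measured as octanol-water partition, at pH 7.4 (a lower number here means a more polar compound, a higher number a more lipophilic compound), the largest of the three numbers shown, though its gaps to compound 2 `COc1cc(/C=C/C(=O)Nc2ccccc2)ccc1OCCCCCN1CCCCC1`, which gives 1.65, and to compound 1 `COc1cc(/C=C/C(=O)Nc2ccccc2)ccc1OCCCCCN(C)C`, which gives 1.61, both fall within the scatter. The change from compound 3 to compound 4 `CCN(CC)CCCCCCCCCCOc1ccc(/C=C/C(=O)Nc2ccccc2)cc1OC` is 4-(diethylamino)butyl in place of piperidin-1-yl on a saturated chain carbon, six bonds along the chain from an oxygen on an aromatic ring. The measured steps that bear on it are a number 0.04 log units higher from compound 1 to compound 2 (within the scatter), a number 0.12 log units higher from compound 2 to compound 3 (within the scatter) and a number 0.16 log units higher from compound 1 to compound 3 (within the scatter), each within the scatter, and each a smaller alteration of the amine end than this one. Since compound 4 gains more heavy atoms in the entering group than any of those steps added, an upward step beyond the scatter is expected, a number 0.38 log units higher from compound 3 to compound 4 (beyond the scatter). Compound 4 is therefore estimated at 2.15, between 1.8 and 2.6.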

Compound 4, partition coefficient: 1.83
The estimate for compound 4 lay 0.32 log units above the measured number, and the stated range covers the measured number.
By their numbers in this assay, from the lowest: compounds 1, 2, 3 and 4 (each within the scatter of the next).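

In this assay, putting 4-(diethylamino)butyl in place of piperidin-1-yl, a swap that adds heavy atoms and opens the ring, gives a number 0.06 log units higher from compound 3 to compound 4 (within the scatter). Read against the earlier compounds, the same amine end gives a number 0.18 log units higher from compound 2 to compound 4 (within the scatter) and a number 0.22 log units higher from compound 1 to compound 4 (within the scatter), so even this larger alteration at the chain end leaves all four compounds within the scatter of one another. No supporting measurement is available to explain this result. On these data alone, whether a morpholine or a carboxylic acid at the chain end would stay within this band remains open. So does the effect of a much shorter chain.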